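The compounds below may be only part of what the source reports. "The series", "measured", "known", "first", "only" and "open" are said of these compounds alone.

Compound 1, with the structure `CC(C)(C)c1ccc(OC(=O)c2cn(-c3ccccc3)nc2-c2cccnc2)cc1`, gives 42300 nM in a functional assay on Raji cells (Homo sapiens) for cytotoxicity, read by MTT assay, with a stated time of 48 h; on this read-out lower numbers stand for stronger inhibition and higher numbers for weaker inhibition. Compound 2, whose structure is `Cc1ccc(C(C)C)c(OC(=O)c2cn(-c3ccccc3)nc2-c2cccnc2)c1`, gives 20600 nM in this assay, and the step of a 2.1-fold lower number from compound 1 to compound 2 (0.31 log units; beyond the scatter) comes from the change (2-isopropyl-5-methylphenyl in place of 4-(tert-butyl)phenyl on an oxygen next to a carbonyl group). Compound 3, with the structure `CC(C)(C)c1ccc(OC(=O)c2cn(-c3ccccc3)nc2-c2ccncc2)cc1`, gives 33300 nM in this assay; it differs from compound 1 only by pyridin-4-yl in place of pyridin-3-yl on an aromatic carbon, and the step of a 1.3-fold lower number from compound 1 to compound 3 (0.10 log units; within the scatter) leaves the two values within the scatter of each other.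

Compound 4, whose structure is `Cc1ccc(C(C)C)c(OC(=O)c2cn(-c3ccccc3)nc2-c2ccncc2)c1`, has not yet been measured in this assay. It carries the change (2-isopropyl-5-methylphenyl in place of 4-(tert-butyl)phenyl on an oxygen next to a carbonyl group), which is the same change that compound 1 undergoes to become compound 2, and it appears twice among these compounds. The core of compound 3 differs from that of compound 1 by pyridin-4-yl in place of pyridin-3-yl on an aromatic carbon, a difference whose own step is within the scatter, so the earlier step is the best guide here. Because the step of a 2.1-fold lower number from compound 1 to compound 2 (0.31 log units; beyond the scatter) was modest but beyond the scatter, compound 4 is expected to show a step of a 2.1-fold lower number from compound 3 to compound 4 (0.32 log units; beyond the scatter) of about the same size, and its value in this assay is estimated at 16000 nM, most likely between 8500 nM and 30000 nM.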

Compound 4, half-maximal inhibitory concentration: 10600 nM
For compound 4 the middle estimate is 1.5-fold (0.18 log units) above the measured one; the range from low to high includes it.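

Replacing 4-(tert-butyl)phenyl with 2-isopropyl-5-methylphenyl carried over to the core of compound 3, where in this assay it gave a 3.1-fold lower number from compound 3 to compound 4 (0.50 log units; beyond the scatter), and its size matched the step on the core of compound 1: the same change on two cores in this assay, a 2.1-fold lower number (0.31 log units; beyond the scatter) from compound 1 to compound 2 and a 3.1-fold lower number (0.50 log units; beyond the scatter) from compound 3 to compound 4, 1.5-fold (0.18 log units) apart, within the scatter of two such steps. The swap of pyridin-3-yl for pyridin-4-yl, seen again as a 1.9-fold lower number from compound 2 to compound 4 (0.29 log units; within the scatter), also behaved alike on both sides, staying inside the usual spread of repeat measurements each time: the same change on two cores in this assay, a 1.3-fold lower number (0.10 log units; within the scatter) from compound 1 to compound 3 and a 1.9-fold lower number (0.29 log units; within the scatter) from compound 2 to compound 4, 1.5-fold (0.18 log units) apart, within the scatter of two such steps. So among these four compounds the two changes act about the same whichever form the other part takes, but two pairs on closely related cores do not show that this would hold on a more different core, and they say nothing about why the numbers move.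

From the compounds shown here alone, it remains open how the series would respond to an amine or a carboxylic acid on the phenyl ring attached to the ester oxygen. Whether an amide linker in place of the ester would keep this pattern is also unanswered.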